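Removing a Methoxy Group From an Inactive Tertiary Amine

This account rests on a few compounds, and the source may have more. Where it says the series, first, only, none or still open, it means among the compounds named here.

Compound 3 `COc1ccc(N(Cc2ccccc2)Cc2ccccc2OC)cc1` stands at the weak end of what has been measured. In a functional assay on L929 cells (Mus musculus) for inhibition, read by MTT assay, with a stated time of 5 days (on this read-out higher numbers stand for weaker inhibition and lower numbers for stronger inhibition), compound 3 gives only a limit of > 40 ug/mL, which is a boundary of the assay rather than a number, as the limit of > 40 ug/mL in this assay, at which 1 of the 3 values shown sits, notes. By contrast, compound 1 `COc1ccc(N(Cc2ccccc2)CC(C)C)cc1` gives 10 ug/mL in this assay, and compound 2 `Cc1ccc(N(Cc2ccccc2)Cc2ccccc2)cc1` gives 11 ug/mL.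

Compound 4 `COc1ccc(N(Cc2ccccc2)Cc2ccccc2)cc1` differs from compound 3 by hydrogen in place of methoxy on an aromatic carbon, so the 2-methoxyphenyl becomes a plain phenyl. Among the compounds with values here, one measured step bears on this: an at least 4.0-fold higher number from compound 1 to compound 3 (0.60 log units; beyond the scatter), where adding that same methoxy-bearing ring weakened inhibition beyond the scatter. Reversing part of that change, by taking the methoxy away, is therefore expected to move in the opposite direction, and compound 4 resembles compound 2 in carrying two unsubstituted benzyl arms.

For compound 4 the expected step is an at least 3.3-fold lower number from compound 3 to compound 4 (0.52 log units; beyond the scatter), a return to stronger inhibition. Compound 4 is estimated at 12 ug/mL, with a likely range from 5 ug/mL to 40 ug/mL.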

Compound 4, half-maximal inhibitory concentration: 12 ug/mL
The estimate for compound 4 equals the measured number at the digits printed; the measured number falls inside the stated range.
By their numbers in this assay, from the lowest: compounds 1, 2 and 4 (each within the scatter of the next). At a limit, above all of these: compound 3.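

In this assay, removing the methoxy from the aromatic carbon ortho to a large group gives an at least 3.3-fold lower number from compound 3 to compound 4 (0.52 log units; beyond the scatter), so this one group on the 2-methoxyphenyl ring separates compound 3 from the other three compounds. The plain second benzyl arm costs nothing measurable: phenyl in place of isopropyl gives a 1.2-fold higher number from compound 1 to compound 4 (0.08 log units; within the scatter), and methoxy in place of methyl on an aromatic carbon gives a 1.1-fold higher number from compound 2 to compound 4 (0.04 log units; within the scatter), both within the scatter. For compound 3 the value remains a limit and not a number, so the full size of the step stays unknown: the limit of > 40 ug/mL in this assay, at which 1 of the 4 values shown sits.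

Going by these compounds, whether the loss is particular to methoxy stays open, since a hydroxyl group, a fluorine or an ethoxy group on that same carbon would be needed to tell. On these data alone, it also remains open what a larger group such as an amine would do there.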